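Hydroxyl groups added to a naphthyloxyacetyl hydrazone scaffold

The compounds below may be only part of what the source reports. "The series", "measured", "known", "first", "only" and "open" are said of these compounds alone.

Two hydrazones sharing one core have been tested in an ADME assay on HEL cells (Homo sapiens) for cytotoxicity; on this read-out lower numbers stand for higher toxicity in this test and higher numbers for lower toxicity in this test. Compound 1 `O=C(COc1cccc2ccccc12)N/N=C/c1cccc(O)c1` gives 100 ug/mL in this assay. Compound 2 `C/C(=N\NC(=O)COc1cccc2ccccc12)c1ccccc1` gives 20 ug/mL in this assay, the lower of the two numbers and therefore the more toxic entry, a gap to compound 1 that lies beyond the usual scatter. Compound 3 `C/C(=N\NC(=O)COc1cccc2ccccc12)c1ccc(O)cc1O` has not yet been measured; it differs from compound 2 by 2,4-dihydroxyphenyl in place of phenyl on a carbon with a double bond to nitrogen. Within the data shown here, no measured pair shows this exact change, so the expectation rests on the two values alone. Compound 1, which carries a hydroxyl on its aromatic ring, sits at the less toxic end, and a move in that direction is expected for compound 3, of moderate size, a 2.5-fold higher number from compound 2 to compound 3 (0.40 log units; beyond the scatter). Compound 3 is therefore estimated at 50 ug/mL in this assay, within a range of 20 ug/mL to 100 ug/mL.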

Compound 3, minimum cytotoxic concentration: > 100 ug/mL
Compound 3 gave a limit, no number (the forecaster's own chance of this, stated with the estimate: 10%); at least 2.0-fold (0.30 log units) between middle value and limit.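

In this assay, among these compounds, putting 2,4-dihydroxyphenyl in place of phenyl on a carbon with a double bond to nitrogen gives an at least 5.0-fold higher number from compound 2 to compound 3 (0.69 log units; beyond the scatter), the first step that isolates a change in one place, and it shows that this swap alone moves the compound toward lower toxicity in this test. Compound 3 is recorded only as a limit, > 100 ug/mL, not as a number. The step therefore gives a minimum size, and how far it extends cannot be read from this result: the limit of > 100 ug/mL in this assay, at which 1 of the 3 values shown sits.

The compounds shown leave open whether one hydroxyl group alone would give a similar step, and which of the two hydroxyl groups matters more. Going by these compounds, how a methoxy group or an amine on the same ring would read in this assay also remains open.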